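Chain length at the ring amine and cytotoxicity

This account rests on a few compounds, and the source may have more. Where it says the series, first, only, none or still open, it means among the compounds named here.

Working notes on the series. In an ADME assay on MT4 cells (Homo sapiens) for cytotoxicity, read by MTT assay, with a stated time of 4 days (on this read-out lower numbers stand for higher toxicity in this test and higher numbers for lower toxicity in this test), compound 1 `CCNc1nc(Nc2ccc(C#N)cc2)nc(Oc2ccc(Cl)c3ccccc23)n1` gives 208000 nM. Compound 2 `CCCNc1nc(Nc2ccc(C#N)cc2)nc(Oc2ccc(Cl)c3ccccc23)n1`, carrying the longer chain, gives 182000 nM in this assay, and the step of a 1.1-fold lower number from compound 1 to compound 2 (0.06 log units; within the scatter) stays within the scatter. Compound 3 `CCNc1nc(Nc2ccc(C#N)cc2)nc(Oc2ccc3cc(Br)ccc3c2Br)n1`, with the other ether substituent, gives 74400 nM in this assay; this is the lowest of the three numbers, and its gaps to compound 2 and to compound 1 both lie beyond the scatter, so compound 3 is the most toxic compound measured here.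

Compound 4 `CNc1nc(Nc2ccc(C#N)cc2)nc(Oc2ccc3cc(Br)ccc3c2Br)n1` differs from compound 3 by hydrogen in place of methyl on a saturated chain carbon bound to a nitrogen on an aromatic ring. For the measured compounds named here, the only measured step that touches this chain is a 1.1-fold lower number from compound 1 to compound 2 (0.06 log units; within the scatter), a lengthening rather than a shortening, carried out on the other ether, and it gave no change beyond the scatter. On that basis no step beyond the scatter is expected in this assay for the shortening either; the expected step for compound 4 is a 1.1-fold higher number from compound 3 to compound 4 (0.03 log units; within the scatter). Compound 4 is therefore estimated at 80000 nM in this assay, with a range from 35000 nM to 180000 nM.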

Compound 4, half-maximal cytotoxic concentration: 92800 nM
Estimate against measurement, compound 4: 1.2-fold (0.06 log units) below; measured number inside the range.
By their numbers in this assay, from the lowest: compounds 3, 4, 2 and 1 (each within the scatter of the next, the first and the last beyond it).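

Shortening ethylamino to methylamino with the other ether substituent gives a 1.2-fold higher number from compound 3 to compound 4 (0.10 log units; within the scatter), so this position now has a reading on a second core and in the shortening direction. The change of one carbon at this saturated chain carbon reads alike on both cores in this assay: the same change on two cores in this assay, a 1.1-fold lower number (0.06 log units; within the scatter) from compound 1 to compound 2 and a 1.2-fold lower number (0.10 log units; within the scatter) from compound 4 to compound 3, 1.1-fold (0.04 log units) apart, within the scatter of two such steps. Across these two pairs, chain length at this place moves the number by no more than the scatter, and no pair shown goes against this.

As far as these compounds go, it remains open whether the bare amino group, a butyl chain, a branched isopropyl group or a hydroxyethyl chain on this nitrogen would also leave the number in place. For the compounds shown here, also open is whether the ether substituents, which are the one difference between compound 1 and compound 3, would keep their spread with other chains on this nitrogen.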